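A Bromo Group Leaves Compound 3

The source may hold more compounds than are shown below. What is called first, only, known or untested is meant among the compounds shown, and "the series" means these compounds.

In a functional assay on MCF7 cells (Homo sapiens) for cytotoxicity, read by sulforhodamine B assay, with a stated time of 48 h (on this read-out lower numbers stand for stronger inhibition and higher numbers for weaker inhibition), compound 2 (`COc1ccc(/C=C/C(=O)c2cccc(-c3ccc(F)cc3)c2)cc1`) gives 16400 nM, and compound 3 (`COc1cc(/C=C/C(=O)c2ccc(N)c(-c3ccc(F)cc3)c2)cc(Br)c1O`) gives 40500 nM. Compound 3 therefore holds the higher of the two numbers, which makes it the weaker inhibitor of this pair, and the gap between them lies beyond the usual scatter of repeated measurements. A third relative adds no number to the comparison, since compound 1 (`COc1ccc(/C=C/C(=O)c2ccc(N)c(-c3ccc(F)cc3)c2)cc1O`) is recorded as "not determined" (no result reported).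

Compound 4 (`COc1cc(/C=C/C(=O)c2ccc(N)c(-c3ccc(F)cc3)c2)ccc1O`) has yet to be measured. It differs from compound 3 by a single change, hydrogen in place of bromo on an aromatic carbon, ortho to a hydroxy group. Among the compounds with values here, no two measured compounds differ in only one place, so the data offer no direct gauge of what this change does. Within the data shown here, the only guide is the range of the measured numbers, with compound 2 at 16400 nM lying under compound 3. A small step toward a lower number is therefore expected, probably not beyond the scatter. The expected size of the change is a 1.6-fold lower number from compound 3 to compound 4 (0.21 log units; within the scatter). For compound 4, the estimated value is 25000 nM, with an expected range from 8000 nM to 70000 nM.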

Compound 4, half-maximal inhibitory concentration: 10500 nM
Beside the measured number, compound 4's estimate is 2.4-fold (0.38 log units) above it, and the stated range covers the measured number.
By their numbers in this assay, from the lowest: compounds 4 and 2 (each within the scatter of the next); then compound 3.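

In this assay, within the data shown here, the change of a 3.9-fold lower number from compound 3 to compound 4 (0.59 log units; beyond the scatter) is the first direct reading of this position, since it compares two compounds that differ in one place only. It shows that the bromo group ortho to the hydroxy group is not needed for cytotoxicity on these cells: with hydrogen on that aromatic carbon, the number falls clearly, and the bromo-bearing compound 3 is the weaker member of the pair. Nothing at hand explains why the number moves this way, so the step records an outcome and not a cause.

The compounds shown place only bromo and hydrogen on this carbon, so they leave open whether a chloro, a methyl or a nitrile group there would give a number close to that of compound 3, close to that of compound 4, or outside both. Going by these compounds, it also remains open whether the same swap would give a step of similar size on a different core, as this single pair cannot establish a general rule for bromo at this position.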